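Trading a Cyclopropyl for a Hydroxymethyl

This account rests on a few compounds, and the source may have more. Where it says the series, first, only, none or still open, it means among the compounds named here.

Of the compounds shown here, three have so far been measured in an assay on a protein complex for inhibition of ubiquitin carboxyl-terminal hydrolase 1/WD repeat-containing protein 48 (Homo sapiens), read by fluorescence; a lower number here means a stronger inhibitor, a higher number a weaker inhibitor. Compound 1 `FC(F)(F)c1ccccc1-c1nc(NCc2ccccc2)c2ccccc2n1` gives 3100 nM, compound 2 `Cc1cnc(-c2ccccc2C(C)C)nc1NCc1ccc(-c2cccnc2)cc1` gives 70 nM, and compound 3 `Cc1cnc(-c2ccccc2C2CC2)nc1NCc1ccc(-c2cccnc2)cc1` gives 180 nM. Compound 3 stands second highest of the three, above compound 2 and well below compound 1. Going by the values given here, the one step that bears on the next change is a 2.6-fold higher number from compound 2 to compound 3 (0.41 log units; beyond the scatter). Compound 4 `Cc1cnc(-c2ccccc2CO)nc1NCc1ccc(-c2cccnc2)cc1` differs from compound 3 by hydroxymethyl in place of cyclopropyl on an aromatic carbon. Since the step from compound 2 to compound 3 already weakened inhibition, the move to compound 4 is expected to give a further modest rise of a 2.8-fold higher number from compound 3 to compound 4 (0.44 log units; beyond the scatter) in this assay. Compound 4 is therefore estimated at 500 nM, with a range from 150 nM to 2000 nM.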

Compound 4, half-maximal inhibitory concentration: 10500 nM
Estimate against measurement, compound 4: 21-fold (1.32 log units) below; measured number outside the range, above it.
By their numbers in this assay, from the lowest: compound 2; then compound 3; then compound 1; then compound 4.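

In this assay, the aromatic carbon ortho to a large group proves far less forgiving than the exchange of two small carbon groups suggested, since hydroxymethyl in place of cyclopropyl brings a 58-fold higher number from compound 3 to compound 4 (1.77 log units; beyond the scatter), well beyond the earlier 2.6-fold higher number from compound 2 to compound 3 (0.41 log units; beyond the scatter). Measured against isopropyl, the same group brings a 150-fold higher number from compound 2 to compound 4 (2.18 log units; beyond the scatter), so this one place spans a very wide range of numbers. Nothing shown here accounts for the jump. The compounds shown leave open whether the hydrogen-bond donor of hydroxymethyl matters, or simply the loss of an all-carbon group. A methoxymethyl or an ethyl group at this place would bear on that question.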